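The source may hold more compounds than are shown below. What is called first, only, known or untested is meant among the compounds shown, and "the series" means these compounds.

Measured compounds in a functional assay on A549 cells (Homo sapiens) for antiproliferative activity, read by MTT assay, with a stated time of 12 h; on this read-out lower numbers stand for stronger inhibition and higher numbers for weaker inhibition:
- Compound 1 `COc1cc(OC)c2c(=O)cc(/C=C/c3ccc(C(F)(F)F)cc3)oc2c1`: compound 1 gives > 40000 nM, which is a limit of the assay, not a number.
- Compound 2 `COc1cc(OC)c2c(=O)cc(/C=C/c3ccc(OC(F)(F)F)cc3)oc2c1`: compound 2 gives 24200 nM.
- Compound 3 `COc1ccc(/C=C/c2cc(=O)c3c(OC)cc(OC)cc3o2)cc1`: compound 3 gives > 40000 nM, again a limit of the assay.

Compound 1 stands at the top edge of what the assay reports; its value is a limit, as the limit of > 40000 nM in this assay, at which 2 of the 3 values shown sit, notes, and it shares that limit with compound 3, so no order between those two can be read. For the measured compounds named here, the only numbered value in the set belongs to compound 2, and the step of an at least 1.6-fold lower number from compound 1 to compound 2 (0.21 log units; that floor lies within the scatter) is a floor that lies within the scatter. The step that the two limits leave unreadable from compound 1 to compound 3 cannot be sized at all, and an at least 1.6-fold higher number from compound 2 to compound 3 (0.21 log units; that floor lies within the scatter) is likewise only a floor within the scatter.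

Compound 4 `COc1cc(OC)c2c(=O)cc(/C=C/c3ccc(OCC4CC4)cc3)oc2c1` carries a cyclopropylmethoxy group in place of trifluoromethyl on an aromatic carbon: cyclopropylmethoxy in place of trifluoromethyl on an aromatic carbon. The closest measured steps are those from compound 1 to compound 2 and from compound 1 to compound 3, where an ether replaces the trifluoromethyl, and neither moves beyond the scatter. Compound 4 is therefore expected to stay near the limit, with a step of an at least 1.1-fold lower number from compound 1 to compound 4 (0.05 log units; that floor lies within the scatter) that is not expected to exceed the scatter. The estimate for compound 4 is 35000 nM, with a range from 15000 nM to 80000 nM.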

Compound 4, half-maximal inhibitory concentration: 20900 nM
Estimate against measurement, compound 4: 1.7-fold (0.22 log units) above; low and high end bracket the measured number.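

In this assay, the oxygen-linked group at this place on the aromatic ring can now be compared between two numbered values, and these cannot be told apart, with a 1.2-fold lower number from compound 2 to compound 4 (0.06 log units; within the scatter); cyclopropylmethyl and trifluoromethyl on that oxygen therefore give the same result within the scatter. Against the compounds held at the limit, the readable steps are an at least 1.9-fold lower number from compound 1 to compound 4 (0.28 log units; that floor lies within the scatter) and an at least 1.9-fold lower number from compound 3 to compound 4 (0.28 log units; that floor lies within the scatter), so neither the replacement of trifluoromethyl by cyclopropylmethoxy nor the addition of cyclopropyl to the methoxy chain can be read as a real gain. Any rule that an ether at this place is enough to bring a compound into the measurable range has compound 3 against it, since its methoxy group leaves it at a limit of the assay: the limit of > 40000 nM in this assay, at which 2 of the 4 values shown sit.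

As far as these compounds go, how far compound 1 and compound 3 lie beyond that limit remains unknown, so the true size of every step involving them stays open. Also open, from the compounds shown here alone, is whether an amine, a carboxylic acid or a longer alkoxy chain at this place, or a change to the two methoxy groups of the shared core, would move the number beyond the scatter.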